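From (3,4-Dimethylphenyl)amino to 4-Hydroxypiperidin-1-yl: an Estimate

The source may report more compounds than this note shows. Statements on the series, on what has been measured and on what is new or still open speak of the compounds shown alone.

Measured compounds:
- compound 1 `Cc1ccc(Nc2nc(C(F)(F)F)ccc2CNC(=O)C(C)c2ccc(NS(C)(=O)=O)c(F)c2)cc1C`: 1160 nM
- compound 2 `CC(C(=O)NCc1ccc(C(F)(F)F)nc1N1CCC(C(F)(F)F)CC1)c1ccc(NS(C)(=O)=O)c(F)c1`: 31 nM

The read-out is a functional assay on CHO-K1 cells for antagonist activity at transient receptor potential cation channel subfamily V member 1 (Homo sapiens), read by FLIPR; on this read-out higher numbers stand for weaker inhibition and lower numbers for stronger inhibition. On this read-out compound 1, with 1160 nM, has the highest of the two numbers, so it is the weaker inhibitor of the pair; the nearest compound is compound 2, and the step of a 37-fold lower number from compound 1 to compound 2 (1.57 log units; beyond the scatter) is a large move toward stronger inhibition.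

Compound 3 `CC(C(=O)NCc1ccc(C(F)(F)F)nc1N1CCC(O)CC1)c1ccc(NS(C)(=O)=O)c(F)c1` has not yet been measured. It differs from compound 1 in one place: 4-hydroxypiperidin-1-yl in place of (3,4-dimethylphenyl)amino on an aromatic carbon.

Going by the values given here, only one measured step bears on this change, a 37-fold lower number from compound 1 to compound 2 (1.57 log units; beyond the scatter), where a piperidine ring likewise took the place of the (3,4-dimethylphenyl)amino group. Compound 3 carries a 4-hydroxypiperidin-1-yl group, which differs from the 4-(trifluoromethyl)piperidin-1-yl group of compound 2, so the full size of that step cannot simply be assumed. The expected outcome is still a move toward lower numbers, estimated as a 4.6-fold lower number from compound 1 to compound 3 (0.67 log units; beyond the scatter). The estimate for compound 3 is 250 nM, in a range from 60 nM to 1000 nM.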

Compound 3, half-maximal inhibitory concentration: "not active" (no number reported)
No number was reported for compound 3, so the estimate cannot be set against anything.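

In this assay, going by these compounds alone, compound 3 is reported as not active, with no number, so no step from compound 1 to compound 3 can be read. No measurement given here offers an explanation for this result. The compounds shown leave open how much weaker, if at all, compound 3 is than compound 1.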